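Swapping a pyridinyl for a phenoxy on a shared core

This account rests on a few compounds, and the source may have more. Where it says the series, first, only, none or still open, it means among the compounds named here.

Of the compounds shown here, two have been measured so far. Compound 1 `O=C(O)/C=C/c1ccc2noc(-c3ccc(-c4ccccc4)cc3)c2c1` carries an acrylic acid arm on the shared core and a phenyl on the distal ring. In an assay for inhibition of inositol hexakisphosphate kinase 2 (Homo sapiens), read by colorimetric assay, coupled enzyme assay and malachite green, with a stated time of 120 min, in the presence of a further agent that is not named here (on this read-out higher numbers stand for weaker inhibition and lower numbers for stronger inhibition), compound 1 gives 74 nM. Compound 2 `O=C(O)c1ccc2noc(-c3ccc(-c4cccnc4)cc3)c2c1` carries the carboxylic acid directly on the core and a pyridin-3-yl on the distal ring. In this assay compound 2 gives 54 nM. Compound 2 has the lower of the two numbers, yet the gap to compound 1 lies within the usual scatter, so the two cannot be told apart on these data.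

Compound 3 `O=C(O)c1ccc2noc(-c3ccc(Oc4ccccc4)cc3)c2c1` has not been measured. It differs from compound 2 in one place: phenoxy in place of pyridin-3-yl on an aromatic carbon. Among the measured compounds shown here, no step between measured compounds covers this kind of change, so the expectation rests on the neighbourhood of the two numbers seen. Because compound 2 gives 54 nM and compound 1 gives 74 nM, the expected step of a 1.6-fold higher number from compound 2 to compound 3 (0.20 log units; within the scatter) is small, if anything toward a weaker reading, and not clearly beyond the scatter. Compound 3 is expected to give 85 nM, with a range from 30 nM to 250 nM.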

Compound 3, half-maximal inhibitory concentration: 280 nM
Compound 3: middle estimate off by 3.3-fold (0.52 log units), on the low side, outside the stated range (above it).
By their numbers in this assay, from the lowest: compounds 2 and 1 (each within the scatter of the next); then compound 3.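

Replacing pyridin-3-yl with phenoxy on this aromatic carbon gives a 5.2-fold higher number from compound 2 to compound 3 (0.71 log units; beyond the scatter) in this assay on an otherwise unchanged structure, so the reading at this position depends on which group sits there, and here the change moves it toward weaker inhibition. The two groups match in hydrogen-bond donors and acceptors, neither carries a net charge, and each contains one six-membered aromatic ring, so these counts do not separate them; they differ in that phenoxy brings an oxygen and a ring of carbon only, whereas pyridin-3-yl has a nitrogen in its ring. No measurement at hand explains the step.

From the compounds shown here alone, what stays open is whether the loss of the ring nitrogen, the arrival of the oxygen or both together account for the higher number. On the same core, a benzyl group, which has carbon where phenoxy has oxygen, and a pyridin-4-yl group, which keeps a ring nitrogen elsewhere in the ring, would each test one part of that question.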